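The compounds below may be only part of what the source reports. "The series", "measured", "known", "first", "only" and "open" are said of these compounds alone.

Compound 1, with the structure `N#Cc1ccc(NC(=O)c2ccc3cccnc3c2O)c(F)c1`, and compound 2, with the structure `Cc1cc(C#N)ccc1NC(=O)c1ccc2cccnc2c1O`, share one core and are both measured in a functional assay on KG-1 cells (Homo sapiens) for cytotoxicity, read by luminescence and CellTiter-Glo, with a stated time of 3 days; a lower number here means a stronger inhibitor, a higher number a weaker inhibitor. In this assay compound 1 gives 3260 nM, and in this assay compound 2 gives 3240 nM. Going by the values given here, the single change between them, (methyl in place of fluoro on an aromatic carbon), produced a 1.0-fold lower number from compound 1 to compound 2 (0.00 log units; within the scatter).

Compound 3, with the structure `N#Cc1ccc(NC(=O)c2c(O)cccc2F)cc1`, is built on a different core. In this assay compound 3 reaches only the limit of the assay, > 10000 nM, so no number is known for it (the limit of > 10000 nM in this assay, at which 1 of the 3 values shown sits). How the core of compound 3 differs from the core of compound 1 is not broken down here.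

Compound 4, with the structure `Cc1cccc(O)c1C(=O)Nc1ccc(C#N)cc1`, has not yet been measured in this assay. It differs from compound 3 by methyl in place of fluoro on an aromatic carbon. Among the compounds with values here, this is the same kind of change as the one from compound 1 to compound 2, but not the same: in compound 2 the methyl sits meta to a cyano group, whereas in compound 4 it sits meta to a hydroxy group.

Because the earlier step gave a 1.0-fold lower number from compound 1 to compound 2 (0.00 log units; within the scatter), the step from compound 3 to compound 4 is expected to be small as well, about a step that the limit leaves unreadable from compound 3 to compound 4. Since compound 3 itself sits only at a limit, compound 4 is expected to give roughly 15000 nM in this assay, somewhere between 5000 nM and 50000 nM, and most likely again only a limit.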

Compound 4, half-maximal inhibitory concentration: 7940 nM
The estimate for compound 4 lay 1.9-fold (0.28 log units) above the measured number; low and high end bracket the measured number.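

In this assay, as far as these compounds go, methyl in place of fluoro on an aromatic carbon gave an at least 1.2-fold lower number from compound 3 to compound 4 (0.10 log units; that floor lies within the scatter), and this is only a floor that does not go beyond the usual scatter, so the true size of the step stays unknown. Compound 3 stands at a limit of the assay, > 10000 nM, and not at a number, so the step on its core may be as small as the one on the core of compound 1 or considerably larger. The result therefore shows that the change can be placed on both cores and that compound 4 gives a readable value, but it does not show that the change carries over with the same size, nor that it carries over differently: the same change on two cores in this assay, a 1.0-fold lower number (0.00 log units; within the scatter) from compound 1 to compound 2 and an at least 1.2-fold lower number (0.10 log units; that floor lies within the scatter) from compound 3 to compound 4; the limit leaves it open whether they differ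

The compounds shown leave open how other groups at this place on the ring, such as an amine, a methoxy group or a carboxylic acid, would read on either core. Going by these compounds alone, with only two pairs, they also leave open whether the change would behave in the same way on any further core.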